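Shortening the side chain of compound 2

This account rests on a few compounds, and the source may have more. Where it says the series, first, only, none or still open, it means among the compounds named here.

Compound 1 `N[C@@H](CC(=O)OC[C@H]1O[C@@H](n2cc(F)c(=O)[nH]c2=O)C[C@@H]1OC(=O)C[C@H](N)C(=O)O)C(=O)O`: 0.27 h
Compound 2 `N[C@@H](CCC(=O)O[C@H]1C[C@H](n2cc(F)c(=O)[nH]c2=O)O[C@@H]1CO)C(=O)O`: 0.132 h

In an ADME assay on tissue (ZR-75-1 cells, Homo sapiens) for pharmacokinetics (on this read-out higher numbers stand for a longer-lived compound and lower numbers for a shorter-lived compound), compound 2 stands lowest of the two measured compounds at 0.132 h. Compound 1 gives 0.27 h, and the gap from compound 2 lies beyond the scatter. Compound 3 `N[C@@H](CC(=O)O[C@H]1C[C@H](n2cc(F)c(=O)[nH]c2=O)O[C@@H]1CO)C(=O)O` differs from compound 2 in one place: amino(carboxy)methyl in place of 2-amino-2-carboxyethyl on a saturated chain carbon bound to a carbonyl carbon. It carries amino(carboxy)methyl in place of 2-amino-2-carboxyethyl on a saturated chain carbon bound to a carbonyl carbon. For the measured compounds named here, no measured pair shows this change, so only a small effect can be expected. In this assay the expected step is a 1.3-fold higher number from compound 2 to compound 3 (0.11 log units; within the scatter), slightly upward and within the scatter. The estimate for compound 3 is 0.17 h, with an expected range of 0.09 h to 0.32 h.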

Compound 3, half-life: 0.403 h
For compound 3 the middle estimate is 2.4-fold (0.37 log units) below the measured one; the measured number lies above the stated range.
By their numbers in this assay, from the lowest: compound 2; then compounds 1 and 3 (each within the scatter of the next).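

In this assay, amino(carboxy)methyl in place of 2-amino-2-carboxyethyl on a saturated chain carbon bound to a carbonyl carbon gives a 3.1-fold higher number from compound 2 to compound 3 (0.48 log units; beyond the scatter) and shows that the half-life responds to this shortening of the chain. Hydrogen in place of (2-amino-2-carboxyethyl)carbonyl on an oxygen on a saturated carbon gives a 1.5-fold higher number from compound 1 to compound 3 (0.17 log units; within the scatter) and so separates these two compounds by no real margin. Nothing on hand explains the step seen with the shorter chain.

On these data alone, it stays open whether both the amine and the carboxylic acid of the side chain are needed for this half-life. A side chain carrying only the amine or only the carboxylic acid would address that.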